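Indole-acrylonitrile series: fluoro for methoxy at the limit

This account rests on a few compounds, and the source may have more. Where it says the series, first, only, none or still open, it means among the compounds named here.

In a functional assay on PC-3 cells (Homo sapiens) for cytotoxicity, read by WST assay, with a stated time of 24 h (a higher number here means a weaker inhibitor, a lower number a stronger inhibitor), compound 2 `COc1ccc2c(C(=O)/C(C#N)=C/c3c[nH]c4ccc(OC)cc34)c[nH]c2c1` gives 31100 nM. Compound 1 `COc1ccc2[nH]cc(/C=C(\C#N)C(=O)c3c[nH]c4cc(F)ccc34)c2c1` differs by fluoro in place of methoxy on an aromatic carbon. In this assay compound 1 returns only a limit, > 50000 nM. The step of an at least 1.6-fold higher number from compound 2 to compound 1 (0.20 log units; that floor lies within the scatter) thus has only a floor, which rests on (the limit of > 50000 nM in this assay, at which 2 of the 3 values shown sit).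

Compound 3 `COc1ccc(Cn2cc(/C=C(\C#N)C(=O)c3c[nH]c4cc(OC)ccc34)c3ccccc32)cc1` has another core; the difference between the two cores is not broken down here. In this assay compound 3 gives only a limit, > 50000 nM. Compound 4 `COc1ccc(Cn2cc(/C=C(\C#N)C(=O)c3c[nH]c4cc(F)ccc34)c3ccccc32)cc1` is reached from compound 3 by the same change, (fluoro in place of methoxy on an aromatic carbon), at a place described in the same words as before.

The step that the limit leaves unreadable from compound 3 to compound 4 is expected to be flat or upward, since compound 3 already sits at the limit > 50000 nM. Compound 4 is therefore estimated at 80000 nM, between 40000 nM and 200000 nM, most likely reported as a limit.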

Compound 4, half-maximal inhibitory concentration: > 50000 nM
Compound 4: only a limit was reported (the forecaster's own chance of this, stated with the estimate: 85%); the middle value lies beyond the limit too.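

In this assay compound 4 gives > 50000 nM, a limit and not a number. Compound 3 also stands at a limit, so no step between compound 3 and compound 4 can be read: the limit of > 50000 nM in this assay, at which 3 of the 4 values shown sit.

The compounds shown leave open whether fluoro in place of methoxy changes cytotoxicity on the core of compound 3.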